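Aryl ether exchange, step from compound 2 to compound 3

A few compounds are considered here, and "the series" means these few. Any claim that something is new, unique, unknown or untested is made for them only; others in the source may bear on it.

Measured so far:
compound 1 `Cc1nn(C)c(Oc2cccc(F)c2)c1/C=N\CCCCCCOc1cc2oc(=O)cc(C)c2cc1Cl`: 23600 nM
compound 2 `Cc1nn(C)c(Oc2ccccc2Br)c1/C=N\CCCCCCOc1cc2oc(=O)cc(C)c2cc1Cl`: 19700 nM

Both values come from a functional assay on SMMC-7721 cells (Homo sapiens) for antiproliferative activity, read by MTT assay, with a stated time of 72 h; a lower number here means a stronger inhibitor, a higher number a weaker inhibitor. Compound 2 and compound 1 sit within the scatter of each other, the step of a 1.2-fold lower number from compound 1 to compound 2 (0.08 log units; within the scatter) being too small to separate them. Compound 3 `Cc1nn(C)c(Oc2cccc(C(F)(F)F)c2)c1/C=N\CCCCCCOc1cc2oc(=O)cc(C)c2cc1Cl` differs from compound 2 by 3-(trifluoromethyl)phenyl in place of 2-bromophenyl on an oxygen on an aromatic ring. Among the measured compounds shown here, the only comparable step is a 1.2-fold lower number from compound 1 to compound 2 (0.08 log units; within the scatter), an exchange of the same aryl group that left the number within the scatter, so no step beyond the scatter is expected in this assay. Compound 3 is therefore estimated at 20000 nM (range 8000 nM to 50000 nM). The expected step is a 1.0-fold higher number from compound 2 to compound 3 (0.01 log units; within the scatter).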

Compound 3, half-maximal inhibitory concentration: 24800 nM
Compound 3: middle estimate off by 1.2-fold (0.09 log units), on the low side; the range from low to high includes it.
By their numbers in this assay, from the lowest: compounds 2, 1 and 3 (each within the scatter of the next).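

In this assay the aryl group on the ether oxygen takes a third substitution pattern with no readable shift (a 1.3-fold higher number from compound 2 to compound 3 (0.10 log units; within the scatter)). The exchange of trifluoromethyl for fluoro on an aromatic carbon, which leaves the rest of compound 1 unchanged, also stays flat (a 1.1-fold higher number from compound 1 to compound 3 (0.02 log units; within the scatter)), so the three halogen-bearing aryl groups shown cannot be told apart here. No supporting data bear on this result.

Going by these compounds, whether an amine or a carboxylic acid on this aryl ring would separate from these values remains open. So does whether a longer chain in place of the linker would.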